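Dropping both oxygen groups from the hydrazone aryl ring

The source may report more compounds than this note shows. Statements on the series, on what has been measured and on what is new or still open speak of the compounds shown alone.

Measured compounds and their values:
- compound 1, `CN(C)CCn1cnnc1-c1cc(Oc2ccc(NC(=O)N/N=C/c3ccc(O)cc3)cc2F)ccn1`: 7750 nM
- compound 2, `CN(C)CCn1cnnc1-c1cc(Oc2ccc(NC(=O)N/N=C/c3c(Cl)cccc3Cl)cc2F)ccn1`: > 100000 nM
- compound 3, `COc1cc(/C=N/NC(=O)Nc2ccc(Oc3ccnc(-c4nncn4CCN(C)C)c3)c(F)c2)ccc1O`: > 100000 nM

All three share one core and differ only in the aryl group on a carbon with a double bond to nitrogen. In a functional assay on U-87MG ATCC cells (Homo sapiens) for cytotoxicity, read by MTT assay, with a stated time of 72 h (on this read-out higher numbers stand for weaker inhibition and lower numbers for stronger inhibition), compound 1 gives 7750 nM. For compound 2 the assay reports only a limit, > 100000 nM. For compound 3 the value is likewise a limit, > 100000 nM, so compound 3 stands at the weak end of what was measured, and it cannot be ranked against compound 2. The two readable steps both run uphill: an at least 12-fold higher number from compound 1 to compound 2 (1.11 log units; beyond the scatter) and an at least 12-fold higher number from compound 1 to compound 3 (1.11 log units; beyond the scatter); the step that the two limits leave unreadable from compound 2 to compound 3 because of the limit of > 100000 nM in this assay, at which 2 of the 3 values shown sit.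

Compound 4, `CN(C)CCn1cnnc1-c1cc(Oc2ccc(NC(=O)N/N=C/c3ccccc3)cc2F)ccn1`, has not yet been measured. Its change from compound 3 is phenyl in place of 4-hydroxy-3-methoxyphenyl on a carbon with a double bond to nitrogen. For the measured compounds named here, no measured step removes the 4-hydroxy group from this aryl ring, so the direction is uncertain; compound 1 shows that an aryl ring with a single 4-hydroxy group still gives a readable number, while compounds 2 and 3 show that other substitution patterns push the value past the limit. The expected step is an at least 3.3-fold lower number from compound 3 to compound 4 (0.52 log units; beyond the scatter). Compound 4 is therefore estimated at 30000 nM, within 8000 nM to 100000 nM.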

Compound 4, half-maximal inhibitory concentration: 2250 nM
Estimate against measurement, compound 4: 13-fold (1.12 log units) above, outside the stated range (below it).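

On the carbon with a double bond to nitrogen, a phenyl ring with no substituent is enough for a readable value in this assay, and removing the single hydroxy gives a 3.4-fold lower number from compound 1 to compound 4 (0.54 log units; beyond the scatter), so the 4-hydroxy group of the earlier readable compound is not needed for activity here. The unsubstituted phenyl also stands clear of both compounds at the limit, with an at least 44-fold lower number from compound 3 to compound 4 (1.64 log units; beyond the scatter) and an at least 44-fold lower number from compound 2 to compound 4 (1.64 log units; beyond the scatter), which makes compound 4 the most potent of the four shown and ties every added ring group in this small set to a higher number. The true sizes of those two large steps stay unknown because of the limit: the limit of > 100000 nM in this assay, at which 2 of the 4 values shown sit.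

Methoxy appears only together with hydroxy and chlorine only as a pair, so the compounds shown cannot separate the contribution of each group or say whether a lone methoxy or a single chlorine would also raise the number. They also leave open how the phenyl ring would read with an amine or a carboxylic acid on it.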